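Compound 2 to compound 4: hydrogen for propyl

The compounds below may be only part of what the source reports. "The series", "measured", "known", "first", "only" and "open" are said of these compounds alone.

Measured in a physicochemical assay for metabolic stability, read by LC-MS, in simulated gastric fluid, with a stated time of 15 min, tested at 50 uM; on this read-out higher numbers stand for a more stable compound and lower numbers for a less stable compound
compound 1 `CCC(=O)c1ccccc1OC(=O)c1coc(-c2ccccc2)n1` gives 1.8%
compound 2 `CCCc1ccccc1OC(=O)c1coc(-c2ccccc2)n1` gives 0.9%
compound 3 `CC(C)(C)c1cccc(C(C)(C)C)c1OC(=O)c1coc(-c2ccccc2)n1` gives 1.3%

In this assay compound 2 stands at 0.9% and lies within the scatter of compound 1 and of compound 3, so no order among the three can be read.

The next compound is compound 4 `O=C(Oc1ccccc1)c1coc(-c2ccccc2)n1`, with hydrogen in place of propyl on an aromatic carbon. Among the compounds with values here, the one measured step that involves the propyl group is a number 0.9 percentage points lower from compound 1 to compound 2 (within the scatter) and it replaces propanoyl with propyl on an aromatic carbon. Compound 3 carries other groups and stands at 1.3% within the scatter of compound 2. Within the data shown here, no measured compound has hydrogen in that place, so the expected range is kept wider on the upper side.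

The expected change is a number 1.1 percentage points higher from compound 2 to compound 4 (within the scatter) and no step beyond the scatter is expected. For compound 4 the estimated value is 2% with an expected range from 0.3% to 10% in this assay.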

Compound 4, percent of the compound remaining: 0.2%
Compound 4: middle estimate off by 1.8 percentage points, on the high side, outside the stated range (below it).
By their numbers in this assay, from the lowest: compounds 4, 2, 3 and 1 (each within the scatter of the next).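

In this assay, hydrogen in place of propyl is a number 0.7 percentage points lower from compound 2 to compound 4 (within the scatter) and hydrogen in place of propanoyl is a number 1.6 percentage points lower from compound 1 to compound 4 (within the scatter). Earlier, this place on the aromatic carbon was compared only between two carbon groups; compound 4 adds the case with no heavy atom there, and it does not separate from compound 1 or compound 2, so neither group can be told from hydrogen on this read-out. No measurement bears on why these compounds read alike.

On these data alone, it remains open whether any group at this place can lift the reading clear of the scatter, for instance an amine, a carboxylic acid or a longer chain on the same aromatic carbon. Also open, as far as these compounds go, is whether a change elsewhere in the shared core would move the number more than changes at this place.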